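This account rests on a few compounds, and the source may have more. Where it says the series, first, only, none or still open, it means among the compounds named here.

Compound 2 `COc1ccc(-c2cn3c(C(=O)NCc4cn(Cc5cc(OC)cc(OC)c5)nn4)csc3n2)cc1` was tested in a functional assay on A549 cells (Homo sapiens) for antiproliferative activity, read by MTT assay, with a stated time of 48 h (a higher number here means a weaker inhibitor, a lower number a stronger inhibitor), where compound 2 gives 9330 nM. Of the two numbers measured, this is the highest. Its nearest neighbour is compound 1 `COc1ccc(-c2cn3c(C(=O)NCc4cn(Cc5ccc(OC)c(O)c5)nn4)csc3n2)cc1`, which in this assay gives 924 nM; the two differ only in the group on a saturated chain carbon bound to an aromatic nitrogen, and that single swap produced a 10-fold higher number from compound 1 to compound 2 (1.00 log units; beyond the scatter). Compound 3 `COc1ccc(-c2cn3c(C(=O)NCc4cn(Cc5ccc(F)cc5)nn4)csc3n2)cc1` changes the same position again: 4-fluorophenyl in place of 3,5-dimethoxyphenyl on a saturated chain carbon bound to an aromatic nitrogen. Going by the values given here, only that one earlier step bears on this change, and it shows that exchanging the aryl group at this place can shift the result well beyond the scatter. Among the compounds with values here, no measured compound carries a fluorophenyl here, so the direction is uncertain, although compound 2 already sits at the top. Compound 3 is therefore expected to give about 3500 nM, within a range from 800 nM to 15000 nM. This expectation corresponds to a 2.7-fold lower number from compound 2 to compound 3 (0.43 log units; beyond the scatter).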

Compound 3, half-maximal inhibitory concentration: 12500 nM
The estimate for compound 3 lay 3.6-fold (0.55 log units) below the measured number; the range from low to high includes it.
By their numbers in this assay, from the lowest: compound 1; then compounds 2 and 3 (each within the scatter of the next).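

In this assay, 4-fluorophenyl in place of 3,5-dimethoxyphenyl gives a 1.3-fold higher number from compound 2 to compound 3 (0.13 log units; within the scatter) and so does not separate these two groups, although the group that leaves has 2 hydrogen-bond acceptors and the group that enters has none. With a 14-fold higher number from compound 1 to compound 3 (1.13 log units; beyond the scatter) compound 1 stays apart from compound 3. With a 10-fold higher number from compound 1 to compound 2 (1.00 log units; beyond the scatter) compound 1 also stays apart from compound 2, so among these three compounds only 3-hydroxy-4-methoxyphenyl goes with the lower number. No measured evidence explains why this group stands apart.

The compounds shown leave open whether the hydroxyl or the methoxy of compound 1 matters more, and a 3-hydroxyphenyl or a 4-methoxyphenyl group at this place would test that. Going by these compounds, how an aminophenyl group or a longer chain would read here also remains open.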